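Permeability of a triazine sulfonylbenzamide series: the carbamate-to-urea step

This account rests on a few compounds, and the source may have more. Where it says the series, first, only, none or still open, it means among the compounds named here.

Compound 1 `CC(C)NCCS(=O)(=O)NC(=O)c1ccc(Nc2nc(NC3(c4ccc(Cl)cc4)CC3)nc(OCC(F)(F)F)n2)cc1` gives 45 nm/s in a physicochemical assay for permeability, using PAMPA, at pH 7.4 (on this read-out lower numbers stand for lower permeability and higher numbers for higher permeability), and compound 2 `CC(C)(C)OC(=O)NCCS(=O)(=O)NC(=O)c1ccc(Nc2nc(NC3(c4ccc(Cl)cc4)CC3)nc(OCC(F)(F)F)n2)cc1` gives 111 nm/s, the highest of the two numbers; the step of a 2.5-fold higher number from compound 1 to compound 2 (0.39 log units; beyond the scatter) is the only one measured. Compound 3 `CNC(=O)NCCS(=O)(=O)NC(=O)c1ccc(Nc2nc(NC3(c4ccc(Cl)cc4)CC3)nc(OCC(F)(F)F)n2)cc1` differs from compound 2 by methylamino in place of tert-butoxy on a carbonyl carbon. Among the measured compounds shown here, no measured step covers this change, so the expectation rests on the range the two values span. Compound 3 is expected to show a 2.8-fold lower number from compound 2 to compound 3 (0.44 log units; beyond the scatter), a value estimated at 40 nm/s, between 15 nm/s and 100 nm/s.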

Compound 3, apparent permeability: 40 nm/s
Estimate against measurement, compound 3: no gap at the digits printed, and the stated range covers the measured number.
By their numbers in this assay, from the lowest: compounds 3 and 1 (each within the scatter of the next); then compound 2.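

In this assay, methylamino in place of tert-butoxy on a carbonyl carbon gives a 2.8-fold lower number from compound 2 to compound 3 (0.44 log units; beyond the scatter), so the group attached to that carbonyl matters at this position. The carbonyl alone does not set compound 2 apart from compound 1: with methylcarbamoyl in place of isopropyl on the amine nitrogen, the comparison gives a 1.1-fold lower number from compound 1 to compound 3 (0.05 log units; within the scatter).

On these data alone, whether an acetyl or an ethoxycarbonyl group on the same nitrogen would read like compound 2 or like compound 3 remains open. The evidence offers no measurement that explains these numbers.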